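This account rests on a few compounds, and the source may have more. Where it says the series, first, only, none or still open, it means among the compounds named here.

In a functional assay on MKN-45 cells (Homo sapiens) for cytotoxicity, read by MTT assay, with a stated time of 48 h (on this read-out lower numbers stand for stronger inhibition and higher numbers for weaker inhibition), compound 1, `CCOC(=O)CSc1nnc(C)n1N1C(=O)c2ccccc2C1=O`, gives only a limit of the assay, > 200000 nM. Compound 2, `C#CCSc1nnc(C)n1N1C(=O)c2ccccc2C1=O`, likewise gives only a limit in this assay, > 200000 nM. Among the measured compounds shown here, the single measured step between them, a step that the two limits leave unreadable from compound 1 to compound 2, cannot be read, since both values sit at the limit of > 200000 nM in this assay, at which 2 of the 2 values shown sit. Compound 2 therefore stands at the limit of this assay, together with compound 1, and no number places it above or below its neighbour.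

Compound 3, `C#CCSc1nnc(CC)n1N1C(=O)c2ccccc2C1=O`, differs from compound 2 by methyl in place of hydrogen on a saturated chain carbon bound to an aromatic carbon. For the measured compounds named here, no measured step touches this kind of change; the one step in hand, from compound 1 to compound 2, concerns a different part of the molecule and has no readable size. What remains is that every value shown in this assay sits at the limit, and a change of one carbon on the substituent bound to an aromatic carbon of the shared core gives no ground to expect compound 3 to leave it. Compound 3 is accordingly estimated at 200000 nM in this assay, with a range from 100000 nM to 400000 nM. This estimate for compound 3 means a step of a number no higher from compound 2 to compound 3 (the limit leaves the size open), expected to be none beyond the scatter.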

Compound 3, half-maximal inhibitory concentration: > 200000 nM
Compound 3: no number, only a limit (the forecaster's own chance of this, stated with the estimate: 85%); the middle value sits exactly at the limit.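

Compound 3, like compound 2, gives only a limit in this assay and so no new step can be read from compound 2 to compound 3, with every value at the same limit: the limit of > 200000 nM in this assay, at which 3 of the 3 values shown sit 

The compounds shown leave open whether any change on the shared core would move a value off this limit, and by how much.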